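A few compounds are considered here, and "the series" means these few. Any claim that something is new, unique, unknown or untested is made for them only; others in the source may bear on it.

Measured compounds:

Compound 1, `Nc1cc(N)c2nc(-c3ccccc3)c(NCc3ccc(Cl)c(Cl)c3)nc2c1`, gives 1660 nM in a functional assay on RPMI8266 cells (Homo sapiens) for inhibition, read by sulforhodamine B assay, with a stated time of 48 h; a lower number here means a stronger inhibitor of growth, a higher number a weaker inhibitor of growth.
Compound 2, `Nc1cc(N)c2nc(-c3ccccc3)c(Sc3ccc(Cl)c(Cl)c3)nc2c1`, gives 3800 nM in this assay.
Compound 3, `CCOC(=O)[C@H](CCC(=O)O)NC(=O)c1ccc(CNc2nc3cc(N)cc(N)c3nc2-c2ccccc2)cc1`, gives 28200 nM in this assay.

Within the data shown here, of the three numbers so far, compound 1 has the lowest, so it is the strongest inhibitor of growth among the compounds measured. Its nearest neighbour is compound 2, whose number is beyond the scatter above that of compound 1, and compound 3 lies much further still.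

Compound 4, `COc1ccc(CNc2nc3cc(N)cc(N)c3nc2-c2ccccc2)cc1`, has not yet been measured. It differs from compound 1 in one place:

4-methoxyphenyl in place of 3,4-dichlorophenyl on a saturated chain carbon bound to a nitrogen on an aromatic ring

Among the measured compounds shown here, no measured pair shows this change, so its effect can only be guessed from the shared core and the numbers already in hand. Weakening of growth inhibition in this assay is expected on going from compound 1 to compound 4, and the expected step is a 2.4-fold higher number from compound 1 to compound 4 (0.38 log units; beyond the scatter), a size that would take compound 4 beyond the scatter but not far. Compound 4 is therefore estimated to give 4000 nM, with a likely range from 1500 nM to 12000 nM.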

Compound 4, concentration for 50% growth inhibition: 4170 nM
The estimate for compound 4 lay 1.0-fold (0.02 log units) below the measured number; measured number inside the range.
By their numbers in this assay, from the lowest: compound 1; then compounds 2 and 4 (each within the scatter of the next); then compound 3.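

The 3,4-dichlorophenyl group on this saturated chain carbon can be exchanged for 4-methoxyphenyl, and in this assay this gives a 2.5-fold higher number from compound 1 to compound 4 (0.40 log units; beyond the scatter) as a modest weakening. Among these compounds, this is the first direct reading of this position, and it shows that the ring's substituents affect growth inhibition while the two chlorines are not needed for compound 4 to keep a measurable effect. Nothing available explains the size of this step.

Open, going by these compounds, is how a ring carrying a single chlorine, such as 4-chlorophenyl, would compare with these two groups, which would help separate the contribution of each substituent. Also open, on these data alone, is how this position would respond to a ring bearing an amine or a carboxylic acid, or to an unsubstituted phenyl.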